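Closing the Amine into a Ring

A few compounds are considered here, and "the series" means these few. Any claim that something is new, unique, unknown or untested is made for them only; others in the source may bear on it.

Three compounds have been measured in a functional assay on the whole organism for inhibition of sodium-dependent dopamine transporter (Mus musculus); a lower number here means that less compound is needed, a higher number that more compound is needed for the effect:
- compound 1 `CCNC(=O)Nc1cccc2c1CN(C)CC2c1ccccc1`: > 80 mg/kg
- compound 2 `CCCNC(=O)Nc1cccc2c1CN(C)CC2c1ccccc1`: > 120 mg/kg
- compound 3 `CCCCNCC(=O)Nc1cccc2c1CN(C)CC2c1ccccc1`: 25 mg/kg

Two of these are not numbers but limits of this assay. For compound 1 the entry > 80 mg/kg is such a limit (the limit of > 80 mg/kg in this assay, at which 1 of the 3 values shown sits). For compound 2 the entry > 120 mg/kg is likewise a limit (the limit of > 120 mg/kg in this assay, at which 1 of the 3 values shown sits). Because both sit at limits, the step that the two limits leave unreadable from compound 1 to compound 2 cannot be read. Within the data shown here, compound 3 therefore stands as the only real number among the three, and it stands lower than both limits: the step of an at least 3.2-fold lower number from compound 1 to compound 3 (0.50 log units; beyond the scatter) and the step of an at least 4.8-fold lower number from compound 2 to compound 3 (0.68 log units; beyond the scatter) are each beyond the scatter. Both of those steps swap the whole group on the carbonyl carbon, from a urea-type arm to a (butylamino)methyl arm.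

Compound 4 `CN1Cc2c(NC(=O)CN3CCCCC3)cccc2C(c2ccccc2)C1` keeps that arm but changes its end: piperidin-1-yl in place of butylamino on a saturated chain carbon bound to a carbonyl carbon. The butylamino is folded into a piperidin-1-yl, so one hydrogen-bond donor leaves. Among the measured compounds shown here, no measured step bears on this particular change; the two readable steps both concern a different swap. The expectation is thus a step of no more than the usual scatter, a 1.1-fold lower number from compound 3 to compound 4 (0.06 log units; within the scatter). Compound 4 is estimated at 22 mg/kg, within a range from 8 mg/kg to 65 mg/kg.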

Compound 4, dose for half-maximal effect: about 60 mg/kg
The estimate for compound 4 lay 2.7-fold (0.44 log units) below the measured number; the range from low to high includes it.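

In this assay, folding the butylamino into a piperidin-1-yl on the saturated chain carbon bound to a carbonyl carbon gives a 2.4-fold higher number from compound 3 to compound 4 (0.38 log units; beyond the scatter), so the end of this arm is not a neutral place to make changes, and the open-chain form needs less compound. The arm with the ring can still be set against the urea-type compounds, with an at least 2.0-fold lower number from compound 2 to compound 4 (0.30 log units; that floor lies within the scatter) and an at least 1.3-fold lower number from compound 1 to compound 4 (0.12 log units; that floor lies within the scatter), but both comparisons start from limits of the assay rather than numbers, and both floors lie within the scatter, so neither one clearly sets compound 4 apart. Nothing measured here explains why the ring form needs more compound.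

The step to compound 4 removes the hydrogen-bond donor and closes the ring at the same time, and the compounds shown do not separate these two changes. As far as these compounds go, an open-chain N-methylbutylamino group, which has no amine hydrogen, or a pyrrolidine or morpholine ring on the same carbon, remains open as a way to tell them apart.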